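Hydroxy-cycloalkylamine variation on a shared nitrile core

The compounds below may be only part of what the source reports. "The series", "measured", "known", "first", "only" and "open" are said of these compounds alone.

Measured compounds:
- compound 1, `N#Cc1cnc(NCc2cnccc2C(F)(F)F)cc1NC[C@H]1C[C@@H](O)C1`: 4200 nM
- compound 2, `N#Cc1cnc(NCc2ccccc2C(F)(F)F)cc1N[C@H]1CC[C@@H](O)CC1`: 4500 nM
- compound 3, `N#Cc1cnc(NCc2cncnc2-c2ccccc2)cc1N[C@H]1CC[C@@H](O)CC1`: 90 nM

In an assay on isolated protein for inhibition of protein kinase C delta type (Homo sapiens), read by TR-FRET, with a stated time of 2 h (a higher number here means a weaker inhibitor, a lower number a stronger inhibitor), compound 1 gives 4200 nM, the second highest number of the three. Compound 2 sits within the scatter of compound 1, so the two cannot be ordered; compound 3 stands far lower, beyond the scatter, and is the strongest inhibitor of the set.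

The next compound, compound 4, `CC1(C)C[C@H](Nc2cc(NCc3cnccc3C(F)(F)F)ncc2C#N)CC[C@@H]1O`, differs from compound 1 in one place: 4-hydroxy-3,3-dimethylcyclohexyl in place of (3-hydroxycyclobutyl)methyl on a nitrogen on an aromatic ring. For the measured compounds named here, no measured pair shows this particular change, so its effect is not known from the numbers. What the set does show is that compound 2, which carries a hydroxycyclohexyl on the same nitrogen together with a different aromatic side arm, gives 4500 nM, close to compound 1. On that basis the step of a 1.2-fold lower number from compound 1 to compound 4 (0.08 log units; within the scatter) is expected to be small, at most a slight move to a lower number, and possibly none beyond the scatter. Compound 4 is therefore estimated at 3500 nM, with a range from 1000 nM to 12000 nM.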

Compound 4, half-maximal inhibitory concentration: 500 nM
Compound 4: the middle estimate sits 7.0-fold (0.85 log units) above what was measured; measured number below the stated range.
By their numbers in this assay, from the lowest: compound 3; then compound 4; then compounds 1 and 2 (each within the scatter of the next).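

In this assay, the group on a nitrogen on an aromatic ring now has a readable effect of its own: with the rest of compound 1 held constant, 4-hydroxy-3,3-dimethylcyclohexyl in place of (3-hydroxycyclobutyl)methyl gives an 8.4-fold lower number from compound 1 to compound 4 (0.92 log units; beyond the scatter). For the compounds shown here, no earlier pair differed in one place, and this position had not yet been seen to move the number. No measurement at hand bears on the reason for this step.

Still open, as far as these compounds go, is which part of the change carries the step: the six-membered ring, the loss of the methyl link or the two extra methyl groups, and a plain 4-hydroxycyclohexyl on the side arm of compound 1 would begin to separate these. From the compounds shown here alone, whether the hydroxyl itself matters is also open, and an amine in its place would address that.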